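The source may report more compounds than this note shows. Statements on the series, on what has been measured and on what is new or still open speak of the compounds shown alone.

Working notes on the series. Compound 1 `C=CC(=O)Nc1ccc(-c2nc(Cl)cc(Nc3ccc(C(=O)Nc4ccc(OC)cc4)cc3)n2)cc1` is recorded in a functional assay on Raji cells (Homo sapiens) for antiproliferative activity, read by MTT assay, with a stated time of 48 h (on this read-out lower numbers stand for stronger inhibition and higher numbers for weaker inhibition), as "not determined" (no result reported), so no result exists for it. Among the measured compounds shown here, compound 2 `C=CC(=O)Nc1ccc(-c2nc(Cl)cc(Nc3ccc(C(=O)Nc4cccc(C)c4)cc3)n2)cc1` is therefore the only member with a number: in this assay compound 2 gives 6980 nM, and with no second number alongside it nothing can be said of its standing relative to the others. Compound 3 `C=CC(=O)Nc1ccc(-c2nc(Cl)cc(Nc3ccc(C(=O)N4CCCC4)cc3)n2)cc1` is not yet measured. It differs from compound 2 in one place: pyrrolidin-1-yl in place of (3-methylphenyl)amino on a carbonyl carbon, an amide of a five-membered saturated ring in place of an aryl amide on the same carbonyl carbon. For the measured compounds named here, no step between two measured compounds exists to calibrate such a change, so the expectation rests on compound 2 alone. A step from compound 2 to compound 3 of a 1.1-fold higher number from compound 2 to compound 3 (0.06 log units; within the scatter) is expected, that is a shift not clearly beyond the scatter, in either direction. For compound 3 the estimate in this assay is 8000 nM, with a range from 2500 nM to 25000 nM.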

Compound 3, half-maximal inhibitory concentration: 19200 nM
For compound 3 the middle estimate is 2.4-fold (0.38 log units) below the measured one; the measured number falls inside the stated range.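

In this assay, pyrrolidin-1-yl in place of (3-methylphenyl)amino on the carbonyl carbon gives a 2.8-fold higher number from compound 2 to compound 3 (0.44 log units; beyond the scatter), the first measured sign that this read-out responds to what sits at this place. The change replaces a six-membered aromatic ring of carbon only and a hydrogen-bond donor with a five-membered non-aromatic ring and no donor, so these differences travel together and this single step cannot separate them. No measurement at hand bears on the cause of this step.

Open, going by these compounds, is whether a methyl(3-methylphenyl)amino group, which keeps the aromatic ring but carries no amide hydrogen, would read closer to compound 2 or compound 3. Also open, on these data alone, is how an open-chain dimethylamino group or a larger morpholin-4-yl ring would read on the same carbonyl carbon.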